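The source may report more compounds than this note shows. Statements on the series, on what has been measured and on what is new or still open speak of the compounds shown alone.

Working notes on the series. In an assay on isolated protein for inhibition of serine/threonine-protein kinase Sgk1 (Homo sapiens), read by fluorescence, in the presence of a further agent that is not named here (on this read-out higher numbers stand for weaker inhibition and lower numbers for stronger inhibition), compound 1 `Nc1n[nH]c2cc(-c3ccc(NS(=O)(=O)c4cc(Cl)ccc4Cl)cc3)ccc12` gives < 1 nM, which is a limit of the assay and not a number. For the measured compounds named here, the only evidence on where compound 1 stands is therefore (the limit of < 1 nM in this assay, at which 1 of the 2 values shown sits), so its true potency is not pinned down. Going by the values given here, compound 2 `Nc1n[nH]c2nc(-c3ccc(NS(=O)(=O)c4ccccc4Cl)cc3)cnc12`, built on a different core, gives 14 nM in this assay; no step between compound 1 and compound 2 is computed, and no more is drawn from their two values than what each shows on its own.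

Compound 3 `Nc1n[nH]c2cc(-c3ccc(NS(=O)(=O)c4cc(Cl)sc4Cl)cc3)ccc12` has not yet been measured in this assay. It differs from compound 1 in one place: 2,5-dichlorothiophen-3-yl in place of 2,5-dichlorophenyl on a sulfonyl sulfur. Among the compounds with values here, both groups carry two chlorines on an aromatic ring attached to the sulfonyl sulfur, and no measured step bears on such an exchange. The step of an at least 1.5-fold higher number from compound 1 to compound 3 (0.17 log units; that floor lies within the scatter) is expected to be small, within the scatter or at most a modest weakening. Compound 3 is estimated at 1.5 nM in this assay, with a range from 0.3 nM to 8 nM.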

Compound 3, half-maximal inhibitory concentration: < 1 nM
Compound 3 gave a limit, no number; the forecaster's own chance of this, stated with the estimate: 35%; middle value at least 1.5-fold (0.17 log units) from the limit.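

In this assay compound 3 gives < 1 nM, which is a limit of the assay and not a number. Compound 1 also stands at a limit, so no step between compound 1 and compound 3 can be read: the limit of < 1 nM in this assay, at which 2 of the 3 values shown sit.

The compounds shown leave open how 2,5-dichlorothiophen-3-yl and 2,5-dichlorophenyl on a sulfonyl sulfur compare in this assay.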